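This account rests on a few compounds, and the source may have more. Where it says the series, first, only, none or still open, it means among the compounds named here.

Measured so far in a physicochemical assay for solubility, read by LC-MS, in phosphate buffer, with a stated time of 24 h, at pH 7.4; a lower number here means a less soluble compound, a higher number a more soluble compound:
Compound 1 `CC(=O)Nc1cc(Nc2cc(NC3CC3)n3ncc(C#N)c3n2)ccc1N1CCC[C@@H](N)C1` gives > 1000000 nM, which is a limit of the assay rather than a number (the limit of > 1000000 nM in this assay, at which 1 of the 3 values shown sits).
Compound 2 `CC(=O)Nc1cc(Nc2cc(NC3CC3)n3ncc(C#N)c3n2)ccc1N1CC[C@@H](N)C1` gives 812000 nM.
Compound 3 `CC(=O)Nc1cc(Nc2cc(NC3CC3)n3ncc(C#N)c3n2)ccc1NCCCO` gives 2000 nM.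

Compound 3 stands lowest of the two numbers shown; its nearest neighbour is compound 2, and the step of a 410-fold lower number from compound 2 to compound 3 (2.61 log units; beyond the scatter) separates them. The step of an at least 500-fold lower number from compound 1 to compound 3 (2.69 log units; beyond the scatter) points the same way, but its floor rests on a limit for compound 1. The step of an at least 1.2-fold lower number from compound 1 to compound 2 (0.09 log units; that floor lies within the scatter) lies within the scatter.

The unmeasured compound 4 `CC(=O)Nc1cc(Nc2cc(NC3CC3)n3ncc(C#N)c3n2)ccc1N1CC[C@H](N)C1` differs from compound 3 by 3-aminopyrrolidin-1-yl in place of (3-hydroxypropyl)amino on an aromatic carbon. Going by the values given here, this is the reverse of the change from compound 2 to compound 3, except that the entering group carries the other configuration at its defined stereocentre; the group itself is the one present in compound 2. The bearing steps are a 410-fold lower number from compound 2 to compound 3 (2.61 log units; beyond the scatter) and an at least 500-fold lower number from compound 1 to compound 3 (2.69 log units; beyond the scatter), both large, so a large rise in this assay is expected on going back to the ring amine. Compound 2 in this assay gives 812000 nM, and compound 4 is expected to land close to it, as the change of configuration alone is not expected to move the number beyond the scatter.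

The estimated step is a 400-fold higher number from compound 3 to compound 4 (2.60 log units; beyond the scatter). Compound 4 is therefore estimated at 800000 nM, with a range from 400000 nM to 1600000 nM.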

Compound 4, solubility: 590000 nM
For compound 4 the middle estimate is 1.4-fold (0.13 log units) above the measured one; low and high end bracket the measured number.
By their numbers in this assay, from the lowest: compound 3; then compounds 4 and 2 (each within the scatter of the next). At a limit, above all of these: compound 1.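

In this assay, the replacement of (3-hydroxypropyl)amino by 3-aminopyrrolidin-1-yl, on the aromatic carbon ortho to the acetamido group, is now seen with the second configuration of the ring: a 300-fold higher number from compound 3 to compound 4 (2.47 log units; beyond the scatter). The large gap to the hydroxypropyl chain is therefore present with both drawn configurations of the 3-aminopyrrolidin-1-yl group, and the step of a 1.4-fold lower number from compound 2 to compound 4 (0.14 log units; within the scatter) shows no readable separation between them in this read-out: the fact that compounds 2 and 4 differ only in the configuration as drawn. The step of an at least 1.6-fold lower number from compound 1 to compound 4 (0.22 log units; that floor lies within the scatter) rests on a limit of the assay, not a number, and cannot be read as a size: the limit of > 1000000 nM in this assay, at which 1 of the 4 values shown sits.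

The compounds shown do not separate the contribution of the ring from that of its primary amine, since the only group without a ring also carries a hydroxyl in place of the amine; a (3-aminopropyl)amino chain and a 3-hydroxypyrrolidin-1-yl ring at the same place would pull these two apart. Also open, going by these compounds, is how a group with no amine or hydroxyl, such as an unsubstituted pyrrolidin-1-yl ring, or one with a carboxylic acid, would stand.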